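The source may hold more compounds than are shown below. What is called first, only, known or untested is meant among the compounds shown, and "the series" means these compounds.

Notes on the series. Compound 1 `COc1ccc(-c2c(C)nn3c(NCc4cccnc4)cc(C)nc23)cc1OC` and compound 2 `COc1ccc(-c2c(C)nn3c(NCC4CCOCC4)cc(C)nc23)cc1OC` share a core; in a physicochemical assay for lipophilicity, at pH 7.4 (a lower number here means a more polar compound, a higher number a more lipophilic compound), compound 1 gives 4.3, and compound 2 gives 5.2. The change between them is oxan-4-yl in place of pyridin-3-yl on a saturated chain carbon bound to a nitrogen on an aromatic ring, and the step it made is a number 0.90 log units higher from compound 1 to compound 2 (beyond the scatter).

Compound 3 `COc1ccc(-c2c(C)nn3c(NCc4cccnc4)nc(C)nc23)cc1OC` sits on a second core; the difference between the two cores is not broken down here. In this assay compound 3 gives 4.5, and compound 1 gives 4.3, two values within the usual scatter of each other. Within the data shown here, compound 4 `COc1ccc(-c2c(C)nn3c(NCC4CCOCC4)nc(C)nc23)cc1OC` is the not yet measured member; it differs from compound 3 by oxan-4-yl in place of pyridin-3-yl on a saturated chain carbon bound to a nitrogen on an aromatic ring, the same change as the one from compound 1 to compound 2, in the same place.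

Among the measured compounds shown here, with only the one earlier step to rest on, the expectation for compound 4 in this assay is a step of about the same size, a number 0.90 log units higher from compound 3 to compound 4 (beyond the scatter), because compound 1 to compound 2 gave a number 0.90 log units higher from compound 1 to compound 2 (beyond the scatter). The estimate for compound 4 is therefore 5.4, expected to fall between 5 and 5.8.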

Compound 4, distribution coefficient: 5.1
Beside the measured number, compound 4's estimate is 0.30 log units above it, within the range that was stated.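

In this assay, oxan-4-yl in place of pyridin-3-yl gives a step in the same direction on both cores: a number 0.60 log units higher from compound 3 to compound 4 (beyond the scatter), alongside a number 0.90 log units higher from compound 1 to compound 2 (beyond the scatter). This supports carrying the direction of the change from the core of compound 1 to the core of compound 3, but it rests on one matched pair per core and does not establish a fixed step size or show that the change will carry to any further core. No measurement shown bears on what underlies either step.

The compounds shown leave open whether the step would persist with a basic amine such as piperidin-4-yl or with a carboxylic acid in place of oxan-4-yl, on a saturated chain carbon bound to a nitrogen on an aromatic ring. They also leave open what a longer chain carrying oxan-4-yl or pyridin-3-yl would give in this assay on either core.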